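Cyclobutyl in Place of Methylcyclohexyl on an Amide

The source may hold more compounds than are shown below. What is called first, only, known or untested is meant among the compounds shown, and "the series" means these compounds.

Compound 2 `CC1CCCC(C(=O)N2CC(c3nc(-c4cccc(Cl)c4)no3)C2)C1` carries a 3-methylcyclohexyl group on the carbonyl carbon of its amide. In an assay on HEK293 cells for negative allosteric modulation of metabotropic glutamate receptor 5 (Homo sapiens), read by FLIPR (on this read-out higher numbers stand for weaker inhibition and lower numbers for stronger inhibition), compound 2 gives > 10000 nM, which is a limit of the assay and not a number. Compound 1 `O=C(C1CCCCC1)N1CC(c2nc(-c3cccc(F)c3)no2)C1`, another amide with a cyclohexyl group, also sits at a limit: in this assay compound 1 gives > 10000 nM. Two of the three values shown therefore rest at the limit of > 10000 nM in this assay, at which 2 of the 3 values shown sit. Compound 3 `Cc1cccc(S(=O)(=O)N2CC(c3nc(-c4cccc(Cl)c4)no3)C2)c1`, a sulfonamide rather than an amide, stands apart from the two amides; in this assay compound 3 gives 390 nM.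

Compound 4 `O=C(C1CCC1)N1CC(c2nc(-c3cccc(Cl)c3)no2)C1` has not yet been measured. It differs from compound 2 by cyclobutyl in place of 3-methylcyclohexyl on a carbonyl carbon. No step between measured compounds is available to size this change, because the two amides shown both rest at the limit of > 10000 nM in this assay, at which 2 of the 3 values shown sit. Compound 4, a third amide, is expected to remain at the limit as well, with no shift beyond the scatter. The expected step is a step that the limit leaves unreadable from compound 2 to compound 4. Compound 4 is estimated at 15000 nM, with a range from 4000 nM to 60000 nM.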

Compound 4, half-maximal inhibitory concentration: 1500 nM
Estimate against measurement, compound 4: 10-fold (1.00 log units) above, and the stated range ends above it.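

In this assay, the group on the carbonyl carbon proves to be a place where an amide of this kind can be read, since cyclobutyl in place of 3-methylcyclohexyl gives an at least 6.6-fold lower number from compound 2 to compound 4 (0.82 log units; beyond the scatter). For compound 2, > 10000 nM is a limit of the assay and not a number, so this step gives only a minimum size: the limit of > 10000 nM in this assay, at which 2 of the 4 values shown sit. The group that leaves has 7 heavy atoms and the group that enters has 4, all carbon in both and with no hydrogen-bond donors or acceptors, so being an amide does not by itself hold compound 4 at the limit.

This one pair cannot separate the size of the ring from the loss of the methyl group. As far as these compounds go, how a cyclopropyl group, a cyclopentyl group or an open chain such as isopropyl would read on this carbonyl carbon remains open.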